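Two Analogs at the Assay Limit and a Trimethoxyphenyl Exchange

This account rests on a few compounds, and the source may have more. Where it says the series, first, only, none or still open, it means among the compounds named here.

Compound 1 `COc1cc(C2CC(c3ccc(Cl)cc3)=NN2c2ccc(-c3ccccc3)nn2)cc(OC)c1OC` gives > 100000 nM in a functional assay on HepG2 cells (Homo sapiens) for antiproliferative activity, read by MTT assay, with a stated time of 24 h (a higher number here means a weaker inhibitor, a lower number a stronger inhibitor), which is a limit of the assay rather than a number.
Compound 2 `COc1ccc(C2=NN(c3ccc(-c4ccccc4)nn3)C(c3ccc(OC)cc3OC)C2)cc1` gives > 100000 nM in this assay, again a limit and not a number.

Within the data shown here, compound 2 therefore stands only at a limit, and the limit of > 100000 nM in this assay, at which 2 of the 2 values shown sit, shows that both values given here sit at that same limit; no step between measured compounds can be read from them. Compound 3 `COc1ccc(C2=NN(c3ccc(-c4ccccc4)nn3)C(c3cc(OC)c(OC)c(OC)c3)C2)cc1` differs from compound 2 in one place: 3,4,5-trimethoxyphenyl in place of 2,4-dimethoxyphenyl on a saturated ring carbon. Among the measured compounds shown here, since no measured step is available, the size of the step in this assay cannot be taken from the data; no change beyond the scatter is expected, and another limit is the most likely outcome. The step from compound 2 to compound 3 is estimated as a number no higher from compound 2 to compound 3 (the limit leaves the size open). Compound 3 is expected at 100000 nM, within 30000 nM to 300000 nM.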

Compound 3, half-maximal inhibitory concentration: > 100000 nM
Compound 3: a limit, no number; the forecaster's own chance of this, stated with the estimate: 75%; the middle value lies on the limit itself.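

Compound 3 gives > 100000 nM in this assay, which is a limit and not a number. No step from compound 1 or compound 2 to compound 3 can therefore be read: the limit of > 100000 nM in this assay, at which 3 of the 3 values shown sit.

The compounds shown leave open whether either exchange changes the result in this assay at all.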